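One added methoxy on compound 2

A few compounds are considered here, and "the series" means these few. Any claim that something is new, unique, unknown or untested is made for them only; others in the source may bear on it.

Compound 1 (`COc1ccc(N(C)c2nc(Cl)nc3c2ncn3Cc2cc(OC)c(OC)c(OC)c2)cc1`) 85000 nM
Compound 2 (`COc1ccc(Cn2cnc3c(Cl)nc(Cl)nc32)cc1OC`) 11000 nM

In a functional assay on AGS cells (Homo sapiens) for antiproliferative activity, read by MTT assay, with a stated time of 48 h (a higher number here means a weaker inhibitor of growth, a lower number a stronger inhibitor of growth), compound 2 gives 11000 nM and holds the lower of the two numbers. Compound 1 gives 85000 nM in the same test. The gap between these two numbers lies beyond the scatter. The move to compound 3 (`COc1cc(Cn2cnc3c(Cl)nc(Cl)nc32)cc(OC)c1OC`) is methoxy in place of hydrogen on an aromatic carbon and puts methoxy in place of hydrogen on an aromatic carbon, ortho to a methoxy group. Among the compounds with values here, no measured pair isolates this change, so no trend can be drawn from the data. The expected step of a 1.1-fold higher number from compound 2 to compound 3 (0.04 log units; within the scatter) stays within the scatter, with no direction favoured. The estimated value for compound 3 is 12000 nM with a range from 4000 nM to 35000 nM in this assay here.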

Compound 3, concentration for 50% growth inhibition: 9400 nM
The estimate for compound 3 lay 1.3-fold (0.11 log units) above the measured number, within the range that was stated.
By their numbers in this assay, from the lowest: compounds 3 and 2 (each within the scatter of the next); then compound 1.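

In this assay the added methoxy, ortho to a methoxy group, brings no readable change (a 1.2-fold lower number from compound 2 to compound 3 (0.07 log units; within the scatter)), so this aromatic carbon takes the group with the number staying within the scatter. The larger difference lies elsewhere: chloro in place of (4-methoxyphenyl)(methyl)amino on an aromatic carbon gives a 9.0-fold lower number from compound 1 to compound 3 (0.96 log units; beyond the scatter) and lies beyond the scatter. Nothing available explains either step. The compounds shown leave open whether a hydroxyl or a longer chain on this aromatic carbon would read differently from methoxy. They also leave open how a plain amine in place of that chloro would read.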